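From Methyl to Pentyl in a Growth Inhibition Series

The source may report more compounds than this note shows. Statements on the series, on what has been measured and on what is new or still open speak of the compounds shown alone.

Compound 1 `O=C1COc2ccccc2N1CCCn1cc(-c2ccccc2)nn1`: 4900 nM
Compound 2 `Cc1ccc(-c2cn(CCCN3C(=O)COc4ccccc43)nn2)cc1`: 1120 nM

In a functional assay on MDA-MB-231 cells (Homo sapiens) for antiproliferative activity, read by sulforhodamine B assay, with a stated time of 48 h (on this read-out higher numbers stand for weaker inhibition of growth and lower numbers for stronger inhibition of growth), compound 2 holds the lower of the two numbers, at 1120 nM. Compound 3 `CCCCCc1ccc(-c2cn(CCCN3C(=O)COc4ccccc43)nn2)cc1` differs from it by butyl in place of hydrogen on a saturated chain carbon bound to an aromatic carbon, with butyl in place of hydrogen on a saturated chain carbon bound to an aromatic carbon. Within the data shown here, the only measured step that bears on this is a 4.4-fold lower number from compound 1 to compound 2 (0.64 log units; beyond the scatter), seen with methyl in place of hydrogen on an aromatic carbon. That single step is thin support, but a similarly modest lowering is expected, namely a 2.2-fold lower number from compound 2 to compound 3 (0.35 log units; beyond the scatter). Compound 3 is estimated at 500 nM, within a range from 150 nM to 2500 nM.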

Compound 3, concentration for 50% growth inhibition: 5000 nM
Compound 3: the middle estimate sits 10-fold (1.00 log units) below what was measured; measured number above the stated range.
By their numbers in this assay, from the lowest: compound 2; then compounds 1 and 3 (each within the scatter of the next).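

The methyl gain at this position does not carry over to a longer chain: in this assay, methyl to pentyl gives a 4.5-fold higher number from compound 2 to compound 3 (0.65 log units; beyond the scatter) and gives back what methyl had won. Compared with the hydrogen of the core, pentyl shows a 1.0-fold higher number from compound 1 to compound 3 (0.01 log units; within the scatter), so the two stand level here. Nothing measured on these compounds offers an explanation for this reversal. The compounds shown leave open where between methyl and pentyl the number turns upward, as an ethyl or propyl chain could tell. They also leave open how an amine or a carboxylic acid would fare at this place.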